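The compounds below may be only part of what the source reports. "The series", "measured", "known", "first", "only" and "open" are said of these compounds alone.

Measured compounds:
Compound 1 `O/N=C(/Nc1cccc(F)c1)c1ccc2occc2c1` gives 20000 nM in an assay on tissue (HeLa cells) for inhibition of Indoleamine 2,3-dioxygenase 1 (Homo sapiens), read by spectrophotometry; on this read-out lower numbers stand for stronger inhibition and higher numbers for weaker inhibition.
Compound 2 `O/N=C(/Nc1cccc(Cl)c1)c1ccc2occc2c1` gives 1500 nM in this assay.
Compound 3 `O/N=C(/Nc1ccc(F)c(F)c1)c1ccc2occc2c1` gives 14000 nM in this assay.

Three close analogues around one shared core have been measured in this assay. Compound 1 and compound 2 differ only by chloro in place of fluoro on an aromatic carbon, and this change gives a 13-fold lower number from compound 1 to compound 2 (1.12 log units; beyond the scatter). Compound 1 and compound 3 differ by fluoro in place of hydrogen on an aromatic carbon, and that difference gives a 1.4-fold lower number from compound 1 to compound 3 (0.15 log units; within the scatter), so compound 1 and compound 3 cannot be separated on this read-out. Compound 2 and compound 3 are separated beyond the scatter, with compound 3 on the higher side.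

The unmeasured compound 4 `O/N=C(/Nc1ccc(F)c(Cl)c1)c1ccc2occc2c1` stands to compound 3 as compound 2 stands to compound 1: the difference is chloro in place of fluoro on an aromatic carbon. The change is the same kind of change as that from compound 1 to compound 2, not the same, since in compound 3 the place is also ortho to a fluoro group (1 heavy atom). Within the data shown here, the only guide is the single measured step, so the expectation rests on that alone. From compound 3 to compound 4 a step of a 9.3-fold lower number from compound 3 to compound 4 (0.97 log units; beyond the scatter) is expected in this assay, roughly matching a 13-fold lower number from compound 1 to compound 2 (1.12 log units; beyond the scatter) because a 1.4-fold lower number from compound 1 to compound 3 (0.15 log units; within the scatter) shows the extra fluoro group changing little on its own. Among the measured compounds shown here, compound 4 is therefore estimated at 1500 nM, with a range of 500 nM to 5000 nM given that only one precedent exists.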

Compound 4, half-maximal inhibitory concentration: 1800 nM
Estimate against measurement, compound 4: 1.2-fold (0.08 log units) below; the measured number falls inside the stated range.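

In this assay, among these compounds, the chloro in place of fluoro change carries over to the core that also holds the extra fluoro group, with a 7.8-fold lower number from compound 3 to compound 4 (0.89 log units; beyond the scatter), and this step does not differ from the earlier one: the same change on two cores in this assay, a 13-fold lower number (1.12 log units; beyond the scatter) from compound 1 to compound 2 and a 7.8-fold lower number (0.89 log units; beyond the scatter) from compound 3 to compound 4, 1.7-fold (0.23 log units) apart, within the scatter of two such steps The fluoro in place of hydrogen change is equally consistent across the two cores, with a 1.2-fold higher number from compound 2 to compound 4 (0.08 log units; within the scatter), so it gives no separable difference on either core: the same change on two cores in this assay, a 1.4-fold lower number (0.15 log units; within the scatter) from compound 1 to compound 3 and a 1.2-fold higher number (0.08 log units; within the scatter) from compound 2 to compound 4, 1.7-fold (0.23 log units) apart, within the scatter of two such steps This agreement covers only two cores that differ by a single fluoro group, so it does not show that either change would carry to a core differing in more than that, and it gives no reason for the size of the chloro step.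

The compounds shown leave open whether this step belongs to chloro alone or would also appear with bromo, methyl or trifluoromethyl in the same place. They also leave open how an amine or a carboxylic acid on this ring would read in this assay, and whether the chloro step would hold once the rest of the shared core is changed.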